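The compounds below may be only part of what the source reports. "The series", "measured", "known", "first", "only" and "open" are said of these compounds alone.

Measured so far:
- compound 1, `Nc1ncnc2c1c(-c1cc(C3CC3)on1)nn2C1CCCCC1`, gives 290 nM in an assay on TT cells for inhibition of proto-oncogene tyrosine-protein kinase receptor Ret variant C634W (Homo sapiens), read by MTT assay, with a stated time of 10 days; a lower number here means a stronger inhibitor of growth, a higher number a weaker inhibitor of growth
- compound 2, `CCc1cc(-c2nn(C(C)C)c3ncnc(N)c23)no1`, gives 2610 nM in this assay
- compound 3, `CC(C)n1nc(/C=N/OCc2ccccc2)c2c(N)ncnc21`, gives 9270 nM in this assay

Of the compounds shown here, three sharing one core have been measured in this assay. Compound 2 stands second highest of the three numbers: compound 3 sits beyond the scatter above it, and compound 1 sits beyond the scatter below it, so compound 2 is the middle of the three.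

Compound 4, `CC(C)c1cc(-c2nn(C(C)C)c3ncnc(N)c23)no1`, has not yet been measured. It differs from compound 2 in one place: methyl in place of hydrogen on a saturated chain carbon bound to an aromatic carbon and a saturated chain carbon. Read one bond further out, the change is ethyl to isopropyl on the same side group.

Among the compounds with values here, no measured pair differs by exactly this change, so the size of the step is uncertain. Compound 1, which carries a cyclopropyl on the same side group, gives 290 nM, and isopropyl is closer in shape to cyclopropyl than ethyl is, so a modest move toward a lower number is expected for compound 4, with a step estimated as a 1.7-fold lower number from compound 2 to compound 4 (0.24 log units; within the scatter). The expected value for compound 4 in this assay is 1500 nM, with a range from 500 nM to 5000 nM.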

Compound 4, concentration for 50% growth inhibition: 5130 nM
Compound 4: middle estimate off by 3.4-fold (0.53 log units), on the low side; measured number outside the range, above it.
By their numbers in this assay, from the lowest: compound 1; then compounds 2, 4 and 3 (each within the scatter of the next, the first and the last beyond it).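

In this assay, putting methyl in place of hydrogen on a saturated chain carbon bound to an aromatic carbon and a saturated chain carbon, which turns ethyl into isopropyl, gives a 2.0-fold higher number from compound 2 to compound 4 (0.29 log units; within the scatter). Within the data shown here, this is the first direct reading of this position, and the step lies within the usual scatter, so compounds 2 and 4 cannot be told apart and this one added carbon has no measurable effect here. Nothing available explains this result.

As far as these compounds go, compound 1 differs from compounds 2 and 4 in more than one place, so the part played by its cyclopropyl group alone remains unknown. Also open, from the compounds shown here alone, is whether a tert-butyl group, a longer chain or an amine on the same side group would shift the number beyond the scatter.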